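Swapping a Furan for a Chlorophenyl on the Shared Core

The source may report more compounds than this note shows. Statements on the series, on what has been measured and on what is new or still open speak of the compounds shown alone.

Three compounds share one core. Compound 1 `COc1cc(-c2cc(-c3cc(C(C)C)c(O)cc3C)[nH]c(=O)c2C#N)ccc1O` gives 37.5% in a functional assay for inhibition, tested at 60 ug/mL; on this read-out lower numbers stand for a weaker effect and higher numbers for a stronger effect at the one concentration tested. Compound 2 `COc1cc(OC)c(-c2cc(-c3cc(C(C)C)c(O)cc3C)[nH]c(=O)c2C#N)c(OC)c1` gives 66% in this assay, and compound 3 `Cc1cc(O)c(C(C)C)cc1-c1cc(-c2ccco2)c(C#N)c(=O)[nH]1` gives 55.2%. Compound 3 thus stands second of the three: compound 2 lies higher, beyond the scatter, and compound 1 lies lower, beyond the scatter. Compound 4 `Cc1cc(O)c(C(C)C)cc1-c1cc(-c2ccccc2Cl)c(C#N)c(=O)[nH]1` differs from compound 3 in one place: 2-chlorophenyl in place of furan-2-yl on an aromatic carbon. Among the compounds with values here, the only measured step at this place is a number 17.7 percentage points higher from compound 1 to compound 3 (beyond the scatter); it compares two other groups, so it bears only loosely here, and no measured change is known for the move from furan-2-yl to 2-chlorophenyl. For compound 4 the expected step is therefore a number 3.2 percentage points lower from compound 3 to compound 4 (within the scatter), within the scatter. Compound 4 is estimated at 52%, in a range from 32% to 72%.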

Compound 4, a percentage reported as inhibition, at one concentration (the size of the read-out at that concentration, not a potency): 26%
Beside the measured number, compound 4's estimate is 26 percentage points above it; the measured number lies below the stated range.
By their numbers in this assay, from the lowest: compound 4; then compound 1; then compound 3; then compound 2.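

Within the data shown here, at this place on the shared core, the earlier compounds showed only a gain when one ring was swapped for another, but this assay now gives a number 29.2 percentage points lower from compound 3 to compound 4 (beyond the scatter) on this change. The 2-chlorophenyl group also falls short of the 4-hydroxy-3-methoxyphenyl group, with a number 11.5 percentage points lower from compound 1 to compound 4 (beyond the scatter) here, so a swap of ring at this carbon can lower the number as well as raise it. From the compounds shown here alone, what a plain phenyl, a thiophene or an amine would give on this carbon stays open. Nothing measured here explains the drop.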